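Adding a Methoxy Group to a Weakly Active Lactam

A few compounds are considered here, and "the series" means these few. Any claim that something is new, unique, unknown or untested is made for them only; others in the source may bear on it.

The study measured growth inhibition in a functional assay on NCI/ADR cells (Homo sapiens) for inhibition, read by sulforhodamine B assay, with a stated time of 48 h (a lower number here means a stronger inhibitor of growth, a higher number a weaker inhibitor of growth), for three compounds. Among the compounds with values here, compound 1 `COc1cc(/C=C/C2CC(=O)C=CO2)cc(OC)c1OC` gives 223 uM, and compound 2 `COc1cc(/C=C/C2CC=CC(=O)O2)cc(OC)c1OC` gives 35.1 uM; the change of ring between them, a 6.4-fold lower number from compound 1 to compound 2 (0.80 log units; beyond the scatter), is the only step in the set. Compound 3 `COc1ccc(/C=C/C2CC=CC(=O)N2)cc1OC` returns only a limit, > 964 uM, so its number is not known, and it sits at the limit of > 964 uM in this assay, at which 1 of the 3 values shown sits.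

The next compound, compound 4 `COc1cc(/C=C/C2CC=CC(=O)N2)cc(OC)c1OC`, differs from compound 3 by methoxy in place of hydrogen on an aromatic carbon. Within the data shown here, no measured pair isolates this change: the one step available, from compound 1 to compound 2, concerns the ring and not the aromatic substituents, so it says nothing direct about (methoxy in place of hydrogen on an aromatic carbon). Compound 4 shares the ring of compound 3 and the aromatic pattern of compound 1 and compound 2, and the author expects it to remain a weak inhibitor, with a step of an at least 1.6-fold lower number from compound 3 to compound 4 (0.20 log units; that floor lies within the scatter) that may again end at the limit. Compound 4 is estimated at 600 uM, between 100 uM and 2000 uM.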

Compound 4, concentration for growth inhibition (reported as GI): > 864 uM
Compound 4 gave a limit, no number (the forecaster's own chance of this, stated with the estimate: 55%); middle value at least 1.4-fold (0.15 log units) away from the limit.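

In this assay compound 4 returns only a limit, not a number: the limit of > 864 uM in this assay, at which 1 of the 4 values shown sits. With limits on both sides, the step for methoxy in place of hydrogen on an aromatic carbon cannot be read, so adding this group to the aromatic ring of compound 3 brings no measurable value into view. With the aromatic pattern held fixed, the change of ring alone now gives an at least 24-fold higher number from compound 2 to compound 4 (1.39 log units; beyond the scatter), and likewise an at least 3.8-fold higher number from compound 1 to compound 4 (0.58 log units; beyond the scatter), so the ring of compound 4 stands apart from both oxygen-containing rings.

As far as these compounds go, what methoxy in place of hydrogen does on the ring of compound 2, where a number can be read, stays open. Also open, from the compounds shown here alone, is whether a methyl group in place of the amide hydrogen of compound 4, or a hydroxyl group in place of a methoxy group, would give a value rather than a limit.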